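The source may report more compounds than this note shows. Statements on the series, on what has been measured and on what is new or still open speak of the compounds shown alone.

Compounds measured so far:
compound 1, `COc1ccc([C@]2(CO)NC[C@@H](O)[C@@H]2O)cc1`, 395000 nM in an assay on isolated protein for inhibition of lysosomal alpha-glucosidase (Rattus norvegicus), read by colorimetric assay; a higher number here means a weaker inhibitor, a lower number a stronger inhibitor
compound 2, `OC[C@@]1(c2ccc(O)cc2)NC[C@@H](O)[C@@H]1O`, 11000 nM in this assay

Compound 2 holds the lowest of the two numbers in this assay; its nearest neighbour is compound 1, and the step of a 36-fold lower number from compound 1 to compound 2 (1.56 log units; beyond the scatter) separates them. Compound 3, `OC[C@@]1(c2ccccc2)NC[C@@H](O)[C@@H]1O`, has not yet been measured. It differs from compound 2 by hydrogen in place of hydroxy on an aromatic carbon. Going by the values given here, only one measured step bears on this change: the step from the methyl ether to the free hydroxy, a 36-fold lower number from compound 1 to compound 2 (1.56 log units; beyond the scatter), which was large. That step shows that this position on the aromatic ring is sensitive, and that the free hydroxy gives a much lower number than the capped one. Among the compounds with values here, no compound with plain hydrogen at this position has been measured, so the direction of the next step rests on inference: removing the hydroxy altogether is expected to cost potency, though probably less than the methyl cap did. Compound 3 is therefore expected to show a 5.5-fold higher number from compound 2 to compound 3 (0.74 log units; beyond the scatter), with an estimated value of 60000 nM (range 15000 nM to 250000 nM).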

Compound 3, half-maximal inhibitory concentration: 904000 nM
Compound 3: middle estimate off by 15-fold (1.18 log units), on the low side; measured number above the stated range.
By their numbers in this assay, from the lowest: compound 2; then compound 1; then compound 3.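

In this assay, an 82-fold higher number from compound 2 to compound 3 (1.91 log units; beyond the scatter) shows that the low number of compound 2 depends on the free hydroxy itself, not merely on the absence of a methyl cap. Hydrogen at this aromatic carbon gives the highest number of the three compounds, and the change to it from the methoxy group is much smaller, at a 2.3-fold higher number from compound 1 to compound 3 (0.36 log units; beyond the scatter), which is still beyond the scatter. Methoxy therefore does not stand midway between hydroxy and hydrogen: compared with hydrogen, it keeps only a small part of the gain seen with the free hydroxy, so capping the oxygen gives up most of what the hydroxy provides.

Nothing at hand accounts for why the free hydroxy has so large an effect. Going by these compounds, it also remains open whether an amine or a carboxylic acid on this aromatic carbon could match the low number of compound 2, and whether a hydroxy elsewhere on the ring would do the same.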